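Notes on the step from compound 2 to compound 3

The source may report more compounds than this note shows. Statements on the series, on what has been measured and on what is new or still open speak of the compounds shown alone.

Among the measured compounds shown here, in a functional assay on MDA-MB-231 cells (Homo sapiens) for cytotoxicity, read by MTT assay (on this read-out higher numbers stand for weaker inhibition and lower numbers for stronger inhibition), compound 2 (`CCCCCCCCCC(O)CN`) gives 4020 nM and holds the only number so far. Compound 1 (`CCCCCCCCCC(O)CNC(C)=O`) is recorded in this assay as "not active" (no number reported) with no number, so compound 2 has no numeric neighbour to be ranked against. Compound 3 (`COC(=O)CCCCCCCCC(O)CN`) has yet to be tested. Its structural change from compound 2 is methoxycarbonyl in place of methyl on a saturated chain carbon, nine bonds along the chain from an oxygen on a saturated carbon and reads as methoxycarbonyl in place of methyl on a saturated chain carbon, nine bonds along the chain from an oxygen on a saturated carbon. For the measured compounds named here, no measured pair covers a change at this place, so the expected direction is a judgement with little support. Weaker inhibition than in compound 2 is expected, by a moderate step beyond the usual scatter in this assay and with a real chance of no number being reported. The estimated step of a 3.7-fold higher number from compound 2 to compound 3 (0.57 log units; beyond the scatter) is correspondingly uncertain. For compound 3 the estimate is 15000 nM with an expected range from 5000 nM to 60000 nM at this stage.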

Compound 3, half-maximal inhibitory concentration: 29800 nM
Compound 3: the middle estimate sits 2.0-fold (0.30 log units) below what was measured; measured number inside the range.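

In this assay, among the compounds shown here, the step of a 7.4-fold higher number from compound 2 to compound 3 (0.87 log units; beyond the scatter) is the first numeric comparison, and it places a real loss of inhibition on methoxycarbonyl in place of methyl on a saturated chain carbon, nine bonds along the chain from an oxygen on a saturated carbon. The earlier compounds shown here could not show this, as compound 1 differs from compound 2 at another place and carries no number, whereas this single change shows that the read-out responds to what stands at this place, though compound 3 still keeps a measurable value. The data at hand offer no explanation for the size or direction of this step.

Whether the loss belongs to the whole methoxycarbonyl group or to a part of it stays open, as a carboxylic acid, a primary amide and a plain longer chain at this place are absent from the compounds shown. Also open, from the compounds shown here alone, is whether the same change would read alike on the acetylated amine of compound 1, which offers no number to serve as a starting point.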